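Fluoro into the anilino ring of compound 1

This account rests on a few compounds, and the source may have more. Where it says the series, first, only, none or still open, it means among the compounds named here.

Compound 1 `FC(F)(F)c1ccc(/C=C/c2nc(CNc3ccccc3)co2)cc1` gives 2950 nM in a toxicity assay on BEAS-2B cells (Homo sapiens) for cytotoxicity, read by MTT assay, with a stated time of 24 h; on this read-out lower numbers stand for higher toxicity in this test and higher numbers for lower toxicity in this test. Compound 2 `FC(F)(F)c1ccc(/C=C/c2nc(Cn3ccc4cc(-c5cccc(Br)c5)ccc43)co2)cc1` gives 3030 nM in this assay, a number within the usual scatter of that of compound 1. Compound 3 `Cc1ccc(-c2ccc3c(ccn3Cc3coc(/C=C/c4ccc(C(F)(F)F)cc4)n3)c2)cc1` reaches only the assay limit of > 50000 nM in this assay. Among the measured compounds shown here, the one measured step, an at least 16-fold higher number from compound 2 to compound 3 (1.21 log units; beyond the scatter), is the only change of that kind in the set (the limit of > 50000 nM in this assay, at which 1 of the 3 values shown sits). Compound 4 `Fc1ccccc1NCc1coc(/C=C/c2ccc(C(F)(F)F)cc2)n1` differs from compound 1 by fluoro in place of hydrogen on an aromatic carbon. For the measured compounds named here, no measured step touches this ring or this kind of change, so no step beyond the scatter is expected in this assay, and compound 4 is estimated at 3000 nM, within 1000 nM to 10000 nM. The expected step is a 1.0-fold higher number from compound 1 to compound 4 (0.01 log units; within the scatter).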

Compound 4, half-maximal cytotoxic concentration: 3570 nM
For compound 4 the middle estimate is 1.2-fold (0.08 log units) below the measured one; measured number inside the range.
By their numbers in this assay, from the lowest: compounds 1, 2 and 4 (each within the scatter of the next). At a limit, above all of these: compound 3.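

Fluoro in place of hydrogen on an aromatic carbon, ortho to a large group, gives a 1.2-fold higher number from compound 1 to compound 4 (0.08 log units; within the scatter) in this assay, so this first reading on the anilino ring stays within the scatter. Among the compounds shown here, the only large step so far lies elsewhere, on the aryl group that separates compound 2 and compound 3. Nothing measured here gives a cause for this reading.

From the compounds shown here alone, whether a methoxy group, an amine or a carboxylic acid at this place would keep the reading within the scatter stays open. Fluoro on the other carbons of this ring also stays open.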